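The source may report more compounds than this note shows. Statements on the series, on what has been measured and on what is new or still open speak of the compounds shown alone.

Measured compounds in an assay on isolated protein for inhibition of protein kinase C zeta type (Homo sapiens), with a stated time of 4 min, tested at 62.5 uM; a lower number here means less inhibition, a higher number more inhibition at the concentration tested (going by the name of the read-out):
Compound 1 `CC(C)(C)C1=NN(c2ccc(F)cc2)C(c2ccc(O)cc2)C1` gives 95.5%.
Compound 2 `Cc1cccc(N2N=C(C(C)(C)C)CC2c2ccc(O)cc2)c1` gives 91.7%.

Compound 2 stands lowest of the two numbers in this assay, and its nearest neighbour is compound 1, a gap within the usual scatter. Compound 3 `CC(C)(C)C1=NN(c2ccc(Cl)cc2Cl)C(c2ccc(O)cc2)C1` differs from compound 2 in one place: 2,4-dichlorophenyl in place of 3-methylphenyl on an amine nitrogen in a ring. Among the compounds with values here, the one measured step at the same place, a number 3.8 percentage points lower from compound 1 to compound 2 (within the scatter), swapped one substituted phenyl for another and stayed within the scatter. For this swap no step beyond the scatter is expected in this assay either. Compound 3 is therefore estimated at 91%, in the range 78% to 99%. This estimate means an expected step of a number 0.7 percentage points lower from compound 2 to compound 3 (within the scatter).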

Compound 3, a percentage reported as inhibition, at one concentration (the size of the read-out at that concentration, not a potency): 71%
Beside the measured number, compound 3's estimate is 20 percentage points above it; the whole stated range lies above it.
By their numbers in this assay, from the lowest: compound 3; then compounds 2 and 1 (each within the scatter of the next).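

In this assay, placing 2,4-dichlorophenyl on the amine nitrogen in the ring gives a number 20.7 percentage points lower from compound 2 to compound 3 (beyond the scatter) and a number 24.5 percentage points lower from compound 1 to compound 3 (beyond the scatter) on the same swap. This position therefore responds to the choice of substituted phenyl, which the exchange of 4-fluorophenyl for 3-methylphenyl, within the scatter, could not show. Nothing available here explains this loss of inhibition.

As far as these compounds go, whether one chlorine, as in 4-chlorophenyl or 2-chlorophenyl, would give the same loss as two remains open. So does how an unsubstituted phenyl or a pyridyl group would behave at this position.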